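Swapping 1H-imidazol-1-yl for 1H-pyrrol-1-yl on a chain

The source may hold more compounds than are shown below. What is called first, only, known or untested is meant among the compounds shown, and "the series" means these compounds.

Measured in a functional assay on KB cells (Homo sapiens) for antiproliferative activity, read by MTT assay, with a stated time of 48 h; on this read-out lower numbers stand for stronger inhibition and higher numbers for weaker inhibition:
- compound 1 `Cn1cc(C2=C(c3nn(CCCN4CCCCC4)c4ncccc34)C(=O)N(c3ccccc3)C2=O)c2ccccc21`: 5600 nM
- compound 2 `Cn1cc(C2=C(c3nn(CCCn4cccc4)c4ncccc34)C(=O)NC2=O)c2ccccc21`: > 100000 nM (a limit, not a number)
- compound 3 `Cn1cc(C2=C(c3nn(CCCn4ccnc4)c4ncccc34)C(=O)N(c3ccccc3)C2=O)c2ccccc21`: 6800 nM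

Among the measured compounds shown here, the only numbers here lie within the scatter of each other, and the single measured step is a 1.2-fold higher number from compound 1 to compound 3 (0.08 log units; within the scatter). Compound 2 gives only a limit, > 100000 nM. For the measured compounds named here, it carries 1H-pyrrol-1-yl but also differs from compound 3 elsewhere, so it sets no size for this step.

Compound 4 `Cn1cc(C2=C(c3nn(CCCn4cccc4)c4ncccc34)C(=O)N(c3ccccc3)C2=O)c2ccccc21` has 1H-pyrrol-1-yl in place of 1H-imidazol-1-yl on a saturated chain carbon, three bonds along the chain from an aromatic nitrogen. The measured step at this same place, between compound 1 and compound 3, stayed within the scatter, so little movement seems likely. The expected change is small, a 1.0-fold lower number from compound 3 to compound 4 (0.02 log units; within the scatter), with no shift beyond the scatter in this assay. Compound 4 is estimated at 6500 nM, with an expected range of 2500 nM to 20000 nM.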

Compound 4, half-maximal inhibitory concentration: > 100000 nM
Compound 4 was reported as a limit (the forecaster's own chance of this, stated with the estimate: 7%); middle value at least 15-fold (1.18 log units) from the limit.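

Unlike the earlier step at this position, the change to 1H-pyrrol-1-yl gives an at least 14-fold higher number from compound 3 to compound 4 (1.16 log units; beyond the scatter), and set against piperidin-1-yl it gives an at least 17-fold higher number from compound 1 to compound 4 (1.25 log units; beyond the scatter). So the group on this chain can matter a great deal, even though 1H-imidazol-1-yl and piperidin-1-yl stayed within the scatter of each other.

The step from compound 2 to compound 4, which adds the phenyl, cannot be read: the limit of > 100000 nM in this assay, at which 2 of the 4 values shown sit. As far as these compounds go, whether an open-chain amine such as dimethylamino or a longer chain carrying 1H-imidazol-1-yl would hold this activity remains open.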